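The compounds below may be only part of what the source reports. "The series", "measured", "known", "first", "only" and "open" are said of these compounds alone.

Compound 3 `O=c1c(O)c(-c2ccc(Cl)cc2)oc2cc(O)cc(O)c12` and compound 1 `CC(C)(C)c1ccc(-c2oc3cc(O)cc(O)c3c(=O)c2O)cc1` share one core, and in a physicochemical assay, read by spectrophotometry, with a stated time of 20 min (a lower number here means a stronger inhibitor, a higher number a weaker inhibitor), compound 3 gives 27900000 nM while compound 1 gives 709000 nM. The change between them is tert-butyl in place of chloro on an aromatic carbon, and it made a step of a 39-fold lower number from compound 3 to compound 1 (1.59 log units; beyond the scatter). Compound 2 `O=C(/C=C/c1ccc(Cl)cc1)c1ccccc1O` rests on a different core; how the two cores differ is not broken down here. In this assay compound 2 gives 6100000 nM. Compound 4 `CC(C)(C)c1ccc(/C=C/C(=O)c2ccccc2O)cc1` carries the same change on this second core: tert-butyl in place of chloro on an aromatic carbon. The step from compound 2 to compound 4 in this assay is expected to be a 15-fold lower number from compound 2 to compound 4 (1.18 log units; beyond the scatter), going the same way as the earlier one but held smaller because the step of a 39-fold lower number from compound 3 to compound 1 (1.59 log units; beyond the scatter) was seen on a different core and may not carry over in full. For compound 4 the expected value is 400000 nM, between 80000 nM and 2000000 nM.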

Compound 4, half-maximal inhibitory concentration: 17100000 nM
The estimate for compound 4 lay 43-fold (1.63 log units) below the measured number, outside the stated range (above it).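

In this assay tert-butyl in place of chloro gave a 39-fold lower number from compound 3 to compound 1 (1.59 log units; beyond the scatter) on one core but a 2.8-fold higher number from compound 2 to compound 4 (0.45 log units; beyond the scatter) on the other, so the same change moved the number in opposite directions, with both steps beyond the scatter. In this series, then, the result of this change on one core did not predict its direction or size on the other, although two pairs cannot give a rule for other cores. Nothing available here accounts for the difference between the two cores. The compounds shown leave open how a methoxy group, an amine or a carboxylic acid in the same place would behave on each core. They also leave open whether the opposite directions are particular to chloro and tert-butyl.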